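The compounds below may be only part of what the source reports. "The series", "measured", "known", "first", "only" and "open" are said of these compounds alone.

Measured compounds:
Compound 1, `CC(=O)N(CNC[C@H]1NC[C@H](O)[C@@H]1O)Cc1ccccc1`, gives 64900 nM in an assay on isolated protein for inhibition of alpha-mannosidase 2 (Homo sapiens); a lower number here means a stronger inhibitor, a higher number a weaker inhibitor.
Compound 2, `O[C@H]1[C@@H](O)CN[C@@H]1CN[C@@H](COCc1ccccc1)c1ccccc1`, gives 68300 nM in this assay.
Compound 3, `O[C@H]1[C@@H](O)CN[C@@H]1CN[C@@H](COCOc1ccc(F)cc1)c1ccccc1`, gives 6470 nM in this assay.

Compound 3 holds the lowest number of the three in this assay, and its distance to the other two is beyond the usual scatter: compound 1 sits a clear step higher, and compound 2 higher still. Among the compounds with values here, the one step that involves compound 3 is an 11-fold lower number from compound 2 to compound 3 (1.02 log units; beyond the scatter), which came from putting a 4-fluorophenoxy in place of a phenyl on the saturated chain carbon bound to the oxygen.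

Compound 4, `O[C@H]1[C@@H](O)CN[C@@H]1CN[C@@H](COCOc1cccc(Br)c1)c1ccccc1`, takes this further out. The change is 3-bromophenyl in place of 4-fluorophenyl on an oxygen on a saturated carbon. Within the data shown here, no measured pair shows a halogenated phenyl traded for another halogenated phenyl, so the step from compound 2 to compound 3 bears on it only loosely: it tells that the phenoxy-bearing chain is where the gain came from, not whether the halogen and its place on the ring matter. With nothing in the data pointing either way, the expected step in this assay is small, and the estimate for compound 4 is a 1.1-fold higher number from compound 3 to compound 4 (0.03 log units; within the scatter), which would not reach beyond the scatter. Compound 4 is therefore expected to give about 7000 nM, in a range from 2000 nM to 25000 nM.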

Compound 4, inhibition constant: 12800 nM
Compound 4: the middle estimate sits 1.8-fold (0.26 log units) below what was measured, within the range that was stated.
By their numbers in this assay, from the lowest: compounds 3 and 4 (each within the scatter of the next); then compounds 1 and 2 (each within the scatter of the next).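

In this assay, 3-bromophenyl in place of 4-fluorophenyl on the oxygen gives a 2.0-fold higher number from compound 3 to compound 4 (0.30 log units; within the scatter), so this change of both the halogen and its place on the ring does not separate the two compounds. The second halogenated phenoxy group also stands clear of the phenyl starting point, with a 5.3-fold lower number from compound 2 to compound 4 (0.73 log units; beyond the scatter), and so the gain seen earlier is not tied to 4-fluorophenoxy alone. No measurement shown here bears on why the numbers fall as they do.

The halogen and its place on the ring changed together in this step, so the compounds shown cannot tell what either change does alone, or whether a plain phenoxy without any halogen would already bring the gain. As far as these compounds go, how the number in this assay would respond to a methoxy, a nitrile or a carboxylic acid on this ring also remains open, as does the response to a longer chain between the oxygen and the ring.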